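A few compounds are considered here, and "the series" means these few. Any claim that something is new, unique, unknown or untested is made for them only; others in the source may bear on it.

Going by the values given here, compound 1, `CCCCC(OC)c1cccc(NC(=O)CCl)c1`, and compound 2, `CCCCC(O)c1cccc(NC(=O)CCCCl)c1`, are the two measured members of this small set. In a functional assay on M21 cells (Homo sapiens) for antiproliferative activity, with a stated time of 48 h (on this read-out higher numbers stand for weaker inhibition and lower numbers for stronger inhibition), compound 1 gives 6900 nM. Compound 2 reaches only a limit of the assay in this assay, reported as > 100000 nM. Compound 2 therefore stands at the edge of the numbers shown, on (the limit of > 100000 nM in this assay, at which 1 of the 2 values shown sits), so its true value is not known, and compound 1 and compound 2 differ in two places at once, so no single step between them is given.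

Compound 3, `CCCCC(OC)c1cccc(NC(=O)CCCCl)c1`, has not yet been measured in this assay. It differs from compound 2 by methyl in place of hydrogen on an oxygen on a saturated carbon. Among the compounds with values here, no measured step carries this change alone, so its size is open. The author expects an at least 1.6-fold lower number from compound 2 to compound 3 (0.22 log units; that floor lies within the scatter), a step of modest size toward stronger inhibition, with a real chance that compound 3 again returns only a limit. Compound 3 is estimated at 60000 nM, within a range from 10000 nM to 300000 nM.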

Compound 3, half-maximal inhibitory concentration: > 100000 nM
Compound 3 gave a limit, no number (the forecaster's own chance of this, stated with the estimate: 55%); middle value at least 1.6-fold (0.22 log units) away from the limit.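

The earlier pair differed in two places at once, but here the methoxy group stays fixed, and 2-chloroethyl in place of chloro on a saturated chain carbon bound to a carbonyl carbon gives an at least 14-fold higher number from compound 1 to compound 3 (1.16 log units; beyond the scatter) in this assay. Going by these compounds alone, this large step toward weaker inhibition ties the loss to that one change on the chain, which the earlier compounds could not do. Compound 3 gives only a limit of the assay, > 100000 nM, so a methoxy group in place of the hydroxy group does not bring back a readable value with this chain. The step from hydroxy to methoxy cannot be read, since both of its ends are limits rather than numbers: the limit of > 100000 nM in this assay, at which 2 of the 3 values shown sit.

What the compounds shown leave open is whether hydroxy in place of methoxy would change the value when the shorter chloro-bearing chain of compound 1 stays in place. From the compounds shown here alone, it is also open whether bromo in place of that chloro, or an ethoxy group in place of the methoxy group, would keep a readable value.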